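Ethoxyphenyl Analogue of a Series Sitting at the Assay Limit

A few compounds are considered here, and "the series" means these few. Any claim that something is new, unique, unknown or untested is made for them only; others in the source may bear on it.

Compound 3 `N#CC1=C(N)Oc2c(c3nc4ccccc4nc3c3ccccc23)C12C(=O)N(Cc1cnnn1-c1cccc(Br)c1)c1ccccc12` belongs to a set of three closely related compounds, alongside compound 1 `N#CC1=C(N)Oc2c(c3nc4ccccc4nc3c3ccccc23)C12C(=O)N(Cc1cnnn1-c1cccc(Cl)c1)c1ccccc12` and compound 2 `N#CC1=C(N)Oc2c(c3nc4ccccc4nc3c3ccccc23)C12C(=O)N(Cc1cnnn1-c1ccccc1Br)c1ccccc12`. In a functional assay on HepG2 cells (Homo sapiens) for antiproliferative activity, read by MTT assay, with a stated time of 48 h (on this read-out lower numbers stand for stronger inhibition and higher numbers for weaker inhibition), compound 1 gives only a limit, > 50000 nM. In this assay compound 2 likewise returns only a limit, > 50000 nM. Compound 3 also gives only a limit in this assay, > 50000 nM. Compound 3 therefore stands where the whole set stands, at the limit of > 50000 nM in this assay, at which 3 of the 3 values shown sit, with no readable number separating it from the others.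

Compound 4 `CCOc1ccc(-n2nncc2CN2C(=O)C3(C(C#N)=C(N)Oc4c3c3nc5ccccc5nc3c3ccccc43)c3ccccc32)cc1` differs from compound 3 in one place: 4-ethoxyphenyl in place of 3-bromophenyl on an aromatic nitrogen. The measured steps within the set are a step that the two limits leave unreadable from compound 1 to compound 2, a step that the two limits leave unreadable from compound 1 to compound 3 and a step that the two limits leave unreadable from compound 2 to compound 3; each joins two limits, so none of them has a size. Among the measured compounds shown here, they show only that exchanging the aryl group on the aromatic nitrogen between a 3-chlorophenyl, a 2-bromophenyl and a 3-bromophenyl brought no compound to a readable value. The move to a 4-ethoxyphenyl is expected to leave compound 4 at the same limit, so a step that the limit leaves unreadable from compound 3 to compound 4 is expected to stay unreadable as well. Compound 4 is estimated at 70000 nM, with a range from 20000 nM to 250000 nM.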

Compound 4, half-maximal inhibitory concentration: > 50000 nM
Compound 4: only a limit was reported (the forecaster's own chance of this, stated with the estimate: 80%); the middle value is on the limit's open side.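

The steps from compound 1, compound 2 and compound 3 to compound 4 cannot be read, as each joins two limits in this assay: the limit of > 50000 nM in this assay, at which 4 of the 4 values shown sit. The compounds shown leave open whether any aryl group on this aromatic nitrogen gives the shared core a readable value.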